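Arylamine in place of the free amine of compound 3

This account rests on a few compounds, and the source may have more. Where it says the series, first, only, none or still open, it means among the compounds named here.

Compound 3 `NC1=C(C(=O)c2ccccc2)C(c2ccc(Br)cc2)N(CCCn2ccnc2)C1=O` gives 149000 nM in a functional assay on U2OS cells (Homo sapiens) for antiproliferative activity, read by MTT assay, with a stated time of 72 h (on this read-out lower numbers stand for stronger inhibition and higher numbers for weaker inhibition), the highest number of the three measured. Compound 1 `CCOC1=C(C(=O)c2ccccc2)C(c2ccc(Br)cc2)N(CCCn2ccnc2)C1=O` gives 21900 nM and compound 2 `CCCCOC1=C(C(=O)c2ccccc2)C(c2ccc(Br)cc2)N(CCCn2ccnc2)C1=O` gives 32400 nM; between them a 1.5-fold higher number from compound 1 to compound 2 (0.17 log units; within the scatter). The two steps to the amine, a 6.8-fold higher number from compound 1 to compound 3 (0.83 log units; beyond the scatter) and a 4.6-fold higher number from compound 2 to compound 3 (0.66 log units; beyond the scatter), are the only ones that touch the position changed here. Compound 4 `O=C(C1=C(Nc2ccc(F)cc2)C(=O)N(CCCn2ccnc2)C1c1ccc(Br)cc1)c1ccccc1` carries 4-fluorophenyl in place of hydrogen on an amine nitrogen. Among the measured compounds shown here, no measured step places a group on this nitrogen, so the expectation rests loosely on the ethoxy- and butoxy-to-amine steps, in which a substituent larger than hydrogen sits on the lower side. A modest lowering is therefore expected, a 3.0-fold lower number from compound 3 to compound 4 (0.47 log units; beyond the scatter), with wide uncertainty. Compound 4 is estimated at 50000 nM, in the range 15000 nM to 160000 nM.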

Compound 4, half-maximal inhibitory concentration: 30000 nM
For compound 4 the middle estimate is 1.7-fold (0.22 log units) above the measured one; the measured number falls inside the stated range.
By their numbers in this assay, from the lowest: compounds 1, 4 and 2 (each within the scatter of the next); then compound 3.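

In this assay, 4-fluorophenyl on the amine nitrogen gives a 5.0-fold lower number from compound 3 to compound 4 (0.70 log units; beyond the scatter), so substitution at this nitrogen recovers a number close to those of the alkoxy compounds. The (4-fluorophenyl)amino group is on a level with butoxy, a 1.1-fold lower number from compound 2 to compound 4 (0.03 log units; within the scatter), and with ethoxy, a 1.4-fold higher number from compound 1 to compound 4 (0.14 log units; within the scatter), so at this carbon the compounds shown do not separate this nitrogen-linked group from the oxygen-linked ones. Nothing available accounts for the step from the free amine.

The compounds shown leave open whether the step needs the aromatic ring or the fluorine. A plain phenyl or a methyl on this nitrogen would separate these.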